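The source may hold more compounds than are shown below. What is called first, only, known or untested is meant among the compounds shown, and "the series" means these compounds.

Three measured compounds share one core: compound 1 `O=C(CCCCCCn1cc(Nc2ncc(Cl)c(Nc3cccc(Cl)c3)n2)cn1)NO`, compound 2 `O=C(CCCCCCn1cc(Nc2ncc(Cl)c(Nc3ccccc3)n2)cn1)NO` and compound 3 `O=C(CCCCCCn1cc(Nc2ncc(C(F)(F)F)c(Nc3ccc(F)cc3)n2)cn1)NO`. In a functional assay on MOLT-4 cells (Homo sapiens) for antiproliferative activity, read by MTT assay, with a stated time of 48 h (a higher number here means a weaker inhibitor, a lower number a stronger inhibitor), compound 1 gives 130 nM, compound 2 gives 160 nM, and compound 3 gives 240 nM. Compound 2 thus sits second highest of the three numbers, with compound 1 nearest and compound 3 furthest, and both gaps fall within the scatter. Among the measured compounds shown here, the only step between measured compounds that differ in one place, a 1.2-fold higher number from compound 1 to compound 2 (0.09 log units; within the scatter), is within the scatter as well.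

Compound 4 `O=C(CCCCCCn1cc(Nc2ncc(Cl)c(NC3CC3)n2)cn1)NO` has not been measured. It differs from compound 2 by cyclopropyl in place of phenyl on a nitrogen on an aromatic ring. For the measured compounds named here, no measured step touches this kind of change: the one step known concerns a chloro on the phenyl, not the swap of the whole phenyl for a cyclopropyl, so it says nothing about the direction or size to expect here. What can be said is that the three measured compounds, which all keep an aromatic ring on that nitrogen, lie close together, so the core tolerates some variation at that place.

Given no direct guide, compound 4 is expected to lie near compound 2 or somewhat weaker, so the expected step of a 2.0-fold higher number from compound 2 to compound 4 (0.30 log units; within the scatter) is modest, and the estimate for compound 4 in this assay is 320 nM, with a range from 110 nM to 950 nM.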

Compound 4, half-maximal inhibitory concentration: 150 nM
For compound 4 the middle estimate is 2.1-fold (0.33 log units) above the measured one, and the stated range covers the measured number.
By their numbers in this assay, from the lowest: compounds 1, 4, 2 and 3 (each within the scatter of the next).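

In this assay, among the compounds shown here, the earlier compounds all carried an aromatic ring on this nitrogen, so they could not show whether such a ring matters here. The step of a 1.1-fold lower number from compound 2 to compound 4 (0.03 log units; within the scatter) shows that going from anilino to cyclopropylamino, with three carbon atoms entering where six leave and no aromatic ring remaining on the nitrogen, does not move the number beyond the scatter, and the step of a 1.2-fold higher number from compound 1 to compound 4 (0.06 log units; within the scatter), with cyclopropyl in place of 3-chlorophenyl, reads the same way. On this core, then, a small non-aromatic ring and an aromatic one cannot be told apart at this place in this assay, and no measurement at hand speaks to why the groups read alike.

As far as these compounds go, it remains open whether an open chain such as ethyl or n-butyl, or a ring carrying an amine such as piperidine, would also read alike on this nitrogen. Also open, from the compounds shown here alone, is whether cyclopropylamino would give a similar number with trifluoromethyl in place of the chloro on the shared core.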